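Swapping Methoxy for Nitro on a Benzyl Nucleoside

The source may report more compounds than this note shows. Statements on the series, on what has been measured and on what is new or still open speak of the compounds shown alone.

Of the compounds shown here, three built on one shared core have been tested in a functional assay on the whole organism (B cells) with Mus musculus as the target; on this read-out lower numbers stand for smaller maximal responses and higher numbers for larger maximal responses. Compound 1 `COc1ccc(Cn2c(=O)n(C3OC(CO)[C@@H](O)[C@H]3O)c3nc(N)nc(O)c32)cc1` gives 44% in this assay, the second highest of the three numbers. Compound 2 `C=CCn1c(=[Se])n(C2OC(CO)[C@@H](O)[C@H]2O)c2nc(N)nc(O)c21` reaches 70% in this assay, a value that lies beyond the scatter above compound 1. Compound 3 `C=CCn1c(=S)n(C2OC(CO)[C@@H](O)C(O)[C@H]2O)c2nc(N)nc(O)c21` gives 5% in this assay, which is beyond the scatter below compound 1. Both neighbours differ from compound 1 in more than one place, so neither pair gives a clean single-change step.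

Compound 4 `Nc1nc(O)c2c(n1)n(C1OC(CO)[C@@H](O)[C@H]1O)c(=O)n2Cc1ccc([N+](=O)[O-])cc1` is the compound to be measured. It differs from compound 1 in exactly one place: nitro in place of methoxy on an aromatic carbon. Among the compounds with values here, nothing among the measured compounds tells how this particular exchange, nitro in place of methoxy on an aromatic carbon, shifts the maximal response, since no pair differing only there has been measured. The safest expectation is therefore a step from compound 1 to compound 4 that stays within the usual scatter, with the direction left open. For compound 4 the estimated value in this assay is 42%, expected to lie between 15% and 70%, which corresponds to an expected step of a number 2 percentage points lower from compound 1 to compound 4 (within the scatter).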

Compound 4, largest response reached (reported as maximal response), in percent of the reference or control that the assay uses: 147%
The estimate for compound 4 lay 105 percentage points below the measured number, and the stated range ends below it.
By their numbers in this assay, from the lowest: compound 3; then compound 1; then compound 2; then compound 4.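

In this assay, the exchange of 4-methoxybenzyl for 4-nitrobenzyl provides the only clean single-change comparison among these compounds, and it gives a number 103 percentage points higher from compound 1 to compound 4 (beyond the scatter). This shows that the maximal response is highly sensitive to the group on this aromatic carbon, since changing that one group while the rest of the molecule stays the same moves the number far beyond the usual scatter. Nothing measured here explains why this exchange has such a large effect.

With only methoxy and nitro to compare at this position, the compounds shown cannot establish a trend, and it remains open what an amine, a carboxylic acid or a plain hydrogen on the same aromatic carbon would give. As far as these compounds go, it also remains open whether the same exchange of methoxy for nitro would produce a step of similar size on a compound whose shared core carries a different group elsewhere, such as the thiocarbonyl in place of the carbonyl.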